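Hydroxamate series: lipophilicity on exchange of the amide substituent

The source may hold more compounds than are shown below. What is called first, only, known or untested is meant among the compounds shown, and "the series" means these compounds.

Measured so far:
compound 1 `C#CCNC(=O)C[C@H](NC(=O)c1ccc(C#Cc2ccccc2)cc1)C(=O)NO`: 3
compound 2 `O=C(NC1(C(=O)NO)CCS(=O)(=O)CC1)c1ccc(C#Cc2ccccc2)cc1`: 3

Both compounds were run in a physicochemical assay for lipophilicity; on this read-out higher numbers stand for higher lipophilicity and lower numbers for lower lipophilicity. Compound 1 gives 3, and compound 2 gives 3; the two values lie within the scatter of each other, so no order between them can be drawn at the digits shown. For the measured compounds named here, no pair of measured compounds differing in a single place is available, so no measured step exists in this set.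

Compound 3 `O=C(C[C@H](NC(=O)c1ccc(C#Cc2ccccc2)cc1)C(=O)NO)NCCCO` is the next compound to be measured in this assay. It differs from compound 1 in one place: 2-hydroxyethyl in place of ethynyl on a saturated chain carbon bound to an amide-type nitrogen.

The expectation for compound 3 is a fall in this assay beyond the scatter, a step of a number 0.80 log units lower from compound 1 to compound 3 (beyond the scatter) from the value of compound 1, which is 3. Compound 3 is therefore estimated at 2.2, with a range from 1.6 to 2.8.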

Compound 3, distribution coefficient: 2
Compound 3: middle estimate off by 0.20 log units, on the high side, within the range that was stated.
By their numbers in this assay, from the lowest: compound 3; then compounds 1 and 2 (each within the scatter of the next).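

For the compounds shown here, the exchange of ethynyl for 2-hydroxyethyl on a saturated chain carbon bound to an amide-type nitrogen gives the first single-place step in this set: in this assay, the read-out shows a number 1.00 log units lower from compound 1 to compound 3 (beyond the scatter). This place therefore registers on the read-out, which compound 1 and compound 2 could not show, as they differ in more than one place. The change removes a triple bond and adds one hydrogen-bond donor and one hydrogen-bond acceptor, but no measurement available here accounts for the step.

This single pair does not separate the loss of the triple bond from the gain of the hydroxyl, and a plain propyl group at this place would help to tell them apart. Going by these compounds, how far the value moves with a longer chain, an amine or a carboxylic acid at this place also stays open.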